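Moving a Methoxy Group on the Pendant Phenyl Ring

The source may hold more compounds than are shown below. What is called first, only, known or untested is meant among the compounds shown, and "the series" means these compounds.

Measured so far:
Compound 1, `COc1ccc(-c2cc(=O)c3cc(NC(C)=O)ccc3o2)cc1`: 226000 nM
Compound 2, `COc1ccccc1-c1oc2ccc(NC(C)=O)cc2c(=O)c1OC`: 154000 nM

Of the compounds shown here, two have been tested in an ADME assay on MT4 cells (Homo sapiens) for cytotoxicity, read by MTT assay, with a stated time of 4 days; a lower number here means that less compound is tolerated, a higher number that more compound is tolerated. In this assay compound 1 gives 226000 nM, and compound 2 gives 154000 nM. Compound 2 has the lower of the two numbers, but its nearest neighbour, compound 1, lies within the usual scatter of repeated measurements, so the two compounds cannot be told apart on these data, and neither can be called better tolerated than the other.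

Compound 3, `COc1ccc(-c2oc3ccc(NC(C)=O)cc3c(=O)c2OC)cc1`, has not yet been measured. Going by the values given here, it is built from the same atoms as compound 2, joined differently; the one change is 4-methoxyphenyl in place of 2-methoxyphenyl on an aromatic carbon. Compound 1 also carries a 4-methoxyphenyl group, and in this assay compound 1 gives 226000 nM, a value within the scatter of compound 2. Both measured compounds are tolerated at high concentrations, so no step beyond the scatter is expected: a 1.2-fold higher number from compound 2 to compound 3 (0.09 log units; within the scatter). Compound 3 is therefore estimated at 190000 nM, with a range from 95000 nM to 380000 nM.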

Compound 3, half-maximal cytotoxic concentration: 369000 nM
Estimate against measurement, compound 3: 1.9-fold (0.29 log units) below, and the stated range covers the measured number.
By their numbers in this assay, from the lowest: compounds 2, 1 and 3 (each within the scatter of the next, the first and the last beyond it).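

In this assay, going by these compounds alone, shifting the methoxy group from 2-methoxyphenyl to 4-methoxyphenyl, on the same aromatic carbon next to the ring oxygen, gives a 2.4-fold higher number from compound 2 to compound 3 (0.38 log units; beyond the scatter) and is the first step in this set that lies beyond the scatter, so two compounds built from the same atoms can be told apart here, although the difference is modest. The other single change, methoxy in place of hydrogen on an aromatic carbon, gives a 1.6-fold higher number from compound 1 to compound 3 (0.21 log units; within the scatter) and stays within the scatter, so with 4-methoxyphenyl in place, this added methoxy group has no effect that can be read in these numbers. No measured evidence is available to explain either result.

Within the data shown here, it remains open whether the step from 2-methoxyphenyl to 4-methoxyphenyl would also appear on a core carrying hydrogen instead of the added methoxy group, since only one such pair of positions can be compared here. The compounds shown also leave open how the numbers would respond to a hydroxyl group, a fluorine atom or an amine in place of the methoxy group on the pendant phenyl ring.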